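Amide nitrogen substituent swap: cytotoxicity notes on compound 2

The compounds below may be only part of what the source reports. "The series", "measured", "known", "first", "only" and "open" are said of these compounds alone.

Measured compounds:
- Compound 1, `COc1ccc(C(=O)/C=C/c2cc(OC)c(OC)cc2OC)c(O)c1`. In an ADME assay on SH-SY5Y cells (Homo sapiens) for cytotoxicity, read by MTT assay, with a stated time of 48 h (a higher number here means a weaker inhibitor, a lower number a stronger inhibitor), compound 1 gives > 100000 nM, which is a limit of the assay.
- Compound 2, `COc1ccc(C(=O)/C=C/c2ccc(C(=O)NC(C)C)cc2)c(O)c1`. In this assay compound 2 gives > 100000 nM, a limit of the assay.
- Compound 3, `CCOCCCOc1ccc(/C=C/C(=O)c2ccc(OC)cc2O)cc1OC`. In this assay compound 3 gives > 100000 nM, a limit of the assay.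

Compound 2 stands nowhere definite: its value in this assay is a limit, not a number, and the other two values shown are limits as well, as the evidence the limit of > 100000 nM in this assay, at which 3 of the 3 values shown sit, makes plain. Among the compounds with values here, no step between measured compounds is available, so nothing within this set shows how any change moves the read-out.

Compound 4, `COc1ccc(C(=O)/C=C/c2ccc(C(=O)Nc3ccc(C)cc3C)cc2)c(O)c1`, differs from compound 2 only at the amide nitrogen: 2,4-dimethylphenyl in place of isopropyl on an amide-type nitrogen. Without a measured step of any kind, the expected move from compound 2 to compound 4 is a number no higher from compound 2 to compound 4 (the limit leaves the size open), that is, none beyond the scatter. The estimate for compound 4 in this assay is 100000 nM, within 30000 nM to 300000 nM, with a strong chance that only a limit is again reported.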

Compound 4, half-maximal inhibitory concentration: > 100000 nM
Compound 4: no number, only a limit; the forecaster's own chance of this, stated with the estimate: 70%; the middle value sits exactly at the limit.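

In this assay, within the data shown here, compound 2 and compound 4 both stand at a limit of the assay, not a number, and no step between them can be read. The compounds shown leave open whether any change at the amide nitrogen moves the read-out at all.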